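The source may report more compounds than this note shows. Statements on the series, on what has been measured and on what is new or still open speak of the compounds shown alone.

Measured so far in a functional assay on PC-3 cells (Homo sapiens) for cytotoxicity, read by MTT assay, with a stated time of 48 h; a lower number here means a stronger inhibitor, a higher number a weaker inhibitor:
- compound 1 `CC1(C)CCC[C@]2(C)[C@@H](CC[C@@](C)(O)/C=C/c3ccccc3)[C@](C)(O)CC[C@@H]12`: 121 nM
- compound 2 `CC1(C)CCC[C@]2(C)[C@@H](CC[C@@](C)(O)/C=C/c3cccc([N+](=O)[O-])c3)[C@](C)(O)CC[C@@H]12`: 153 nM

Going by the values given here, compound 2 sits within the usual scatter of compound 1, the only other compound measured, so neither stands apart. Compound 3 `Cc1ccc(C)c(/C=C/[C@](C)(O)CC[C@@H]2[C@@]3(C)CCCC(C)(C)[C@@H]3CC[C@@]2(C)O)c1` is not yet measured and differs from compound 2 by 2,5-dimethylphenyl in place of 3-nitrophenyl on a double-bonded chain carbon bound to a double-bonded chain carbon. Among the compounds with values here, one measured step bears on this change: nitro in place of hydrogen on an aromatic carbon gave a 1.3-fold higher number from compound 1 to compound 2 (0.10 log units; within the scatter). Within the data shown here, no measured compound carries 2,5-dimethylphenyl, so this is weak guidance. The expected size is a 1.1-fold lower number from compound 2 to compound 3 (0.05 log units; within the scatter), which means no expected change beyond the scatter. For compound 3 the estimate is 135 nM, with an expected range from 55 nM to 330 nM.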

Compound 3, half-maximal inhibitory concentration: 176 nM
Compound 3: middle estimate off by 1.3-fold (0.12 log units), on the low side; the range from low to high includes it.
By their numbers in this assay, from the lowest: compounds 1, 2 and 3 (each within the scatter of the next).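

Placing 2,5-dimethylphenyl on this double-bonded chain carbon gives a 1.2-fold higher number from compound 2 to compound 3 (0.06 log units; within the scatter) and a 1.5-fold higher number from compound 1 to compound 3 (0.16 log units; within the scatter) in this assay and both steps lie within the scatter. The aromatic ring at this position has now carried two methyl groups as well as a nitro group or neither, and the three compounds cannot be told apart by their numbers. Nothing measured here explains this. Still open, from the compounds shown here alone, is whether an amine or a carboxylic acid on the ring, or a cyclohexyl ring in its place, would move the number beyond the scatter.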